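The source may hold more compounds than are shown below. What is called first, only, known or untested is meant among the compounds shown, and "the series" means these compounds.

Measured in a functional assay on A549 cells (Homo sapiens) for antiproliferative activity, read by MTT assay, with a stated time of 72 h; a higher number here means a weaker inhibitor, a lower number a stronger inhibitor:
Compound 1 `CCCCCCCCCCCCCCNC[C@@H]1OC[C@H](N)[C@H]1O`: 20000 nM
Compound 2 `CCCCCCCNC[C@@H]1OC[C@H](N)[C@H]1O`: > 128000 nM, a limit of the assay and not a number
Compound 3 `CCCCCCCCCCCNC[C@@H]1OC[C@H](N)[C@H]1O`: 9650 nM

Compound 3 has the lowest number of the three in this assay, and the nearest value is that of compound 1, with a 2.1-fold lower number from compound 1 to compound 3 (0.32 log units; beyond the scatter). Compound 4 `CCCCCCCCNC[C@@H]1OC[C@H](N)[C@H]1O` keeps the shared core and differs from compound 3 in the chain on the amine nitrogen: hydrogen in place of propyl on a saturated chain carbon, eight bonds along the chain from an amine nitrogen. Its chain is shorter than that of compound 3 and longer than that of compound 2.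

The closest measured step is an at least 13-fold lower number from compound 2 to compound 3 (1.12 log units; beyond the scatter), and the new change undoes most of that lengthening. Shortening also raised the number in an at least 6.4-fold higher number from compound 1 to compound 2 (0.80 log units; beyond the scatter). Compound 1 shows that the trend is not uniform, since a 2.1-fold lower number from compound 1 to compound 3 (0.32 log units; beyond the scatter) is a shortening that lowers the number. A large step towards a higher number, and so a weaker inhibitor, is therefore expected in this assay. The expected change is a 7.3-fold higher number from compound 3 to compound 4 (0.86 log units; beyond the scatter). Compound 4 is estimated at 70000 nM, with an expected range of 25000 nM to 150000 nM.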

Compound 4, half-maximal inhibitory concentration: 71800 nM
Estimate against measurement, compound 4: 1.0-fold (0.01 log units) below, within the range that was stated.
By their numbers in this assay, from the lowest: compound 3; then compound 1; then compound 4. At a limit, above all of these: compound 2.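

In this assay, the chain on the amine nitrogen now has a true number on the shorter side of compound 3, and the change of hydrogen in place of propyl on a saturated chain carbon, eight bonds along the chain from an amine nitrogen, gives a modest step: a 7.4-fold higher number from compound 3 to compound 4 (0.87 log units; beyond the scatter). With the longer chain, a 3.6-fold higher number from compound 1 to compound 4 (0.56 log units; beyond the scatter), so the lowest number among the three measured values now sits at a middle chain length, with a higher number on each side, and compound 1 goes against any reading that a longer chain always lowers the number. Compound 2 stands at a limit of the assay and not a number: the limit of > 128000 nM in this assay, at which 1 of the 4 values shown sits. Measured from that limit, an at least 1.7-fold lower number from compound 2 to compound 4 (0.25 log units; that floor lies within the scatter), so this step sets no order between the two.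

Chains of lengths lying between those of compound 4 and compound 3, or between those of compound 3 and compound 1, remain open, so the length that gives the lowest number is only bracketed. Also open, on these data alone, is whether a branched chain, a chain ending in a hydroxyl or a carboxylic acid, or an amide in place of the amine would keep the number of compound 3.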